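Chloro entry on the core of compound 2: cytotoxicity notes

This account rests on a few compounds, and the source may have more. Where it says the series, first, only, none or still open, it means among the compounds named here.

Measured so far:
compound 1, `O=C(O)c1c(O)cc(Cl)cc1C=Cc1ccc2ccccc2c1`: 38000 nM
compound 2, `O=C(O)c1c(O)cccc1CCc1ccc2ccccc2c1`: > 100000 nM, a limit of this assay
compound 3, `COc1cc(C=Cc2ccc3ccccc3c2)c(C(=O)O)c(OC)c1`: > 100000 nM, a limit of this assay

In an ADME assay on HEK293 cells (Homo sapiens) for cytotoxicity, read by resazurin assay, with a stated time of 24 h (on this read-out higher numbers stand for lower toxicity in this test and lower numbers for higher toxicity in this test), compound 1 gives 38000 nM. For compound 2 the value > 100000 nM is a limit of this assay and not a number. For compound 3 the value > 100000 nM is likewise a limit. Compound 2 therefore stands at the limit of > 100000 nM in this assay, at which 2 of the 3 values shown sit, and only compound 1 gives a number in this assay. Compound 4, `O=C(O)c1c(O)cc(Cl)cc1CCc1ccc2ccccc2c1`, differs from compound 2 by chloro in place of hydrogen on an aromatic carbon. For the measured compounds named here, no measured step covers this change. Compound 1, carrying both a chloro and a hydroxy group, gives a number below the limit, so a moderate move toward higher toxicity is expected; the step of an at least 1.6-fold lower number from compound 2 to compound 4 (0.22 log units; that floor lies within the scatter) is the estimate. Compound 4 is estimated at 60000 nM, within 20000 nM to 150000 nM.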

Compound 4, half-maximal cytotoxic concentration: 35000 nM
The estimate for compound 4 lay 1.7-fold (0.23 log units) above the measured number; measured number inside the range.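

In this assay, for the compounds shown here, chloro in place of hydrogen on an aromatic carbon, para to a carboxy group, brings an at least 2.8-fold lower number from compound 2 to compound 4 (0.45 log units; beyond the scatter), the first measured step at this position. Compound 1 gives 38000 nM and compound 4 gives 35000 nM, values within the usual scatter of each other, so these two chloro compounds do not separate. The full size of the step cannot be read because compound 2 sits at a limit: the limit of > 100000 nM in this assay, at which 2 of the 4 values shown sit.

From the compounds shown here alone, whether an amine or a nitrile in place of chloro at this position would give a similar number remains open.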